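The source may hold more compounds than are shown below. What is called first, only, known or untested is meant among the compounds shown, and "the series" means these compounds.

Compound 1 (`COc1ccc(C(=O)Nc2ccc3c(c2)/C(=C/Nc2cccc(N4CCN(C)CC4)c2)C(=O)N3)cc1`), compound 2 (`CN1CCN(c2cccc(N/C=C3\C(=O)Nc4ccc(NC(=O)c5c(Cl)cccc5Cl)cc43)c2)CC1`), compound 3 (`CC(C)CC(=O)Nc1ccc2c(c1)/C(=C/Nc1cccc(N3CCN(C)CC3)c1)C(=O)N2`) and compound 4 (`CN1CCC(C(=O)Nc2ccc3c(c2)/C(=C/Nc2cccc(N4CCN(C)CC4)c2)C(=O)N3)CC1`) share one core and differ only in the group on a carbonyl carbon. In a functional assay on HCT-116 cells (Homo sapiens) for inhibition, read by sulforhodamine B assay, with a stated time of 3 days (on this read-out higher numbers stand for weaker inhibition and lower numbers for stronger inhibition), compound 1 gives 2010 nM. In this assay, compound 2 gives 2280 nM. Compound 3 gives 9410 nM, the highest of the three numbers, which makes it the weakest inhibitor measured so far.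

The next change puts 1-methylpiperidin-4-yl in place of isobutyl on that carbonyl carbon: 1-methylpiperidin-4-yl in place of isobutyl on a carbonyl carbon. Going by the values given here, three measured steps bear on it. Exchanging one ring-bearing group for another, 2,6-dichlorophenyl for 4-methoxyphenyl, gives a 1.1-fold higher number from compound 1 to compound 2 (0.05 log units; within the scatter). Isobutyl in place of 4-methoxyphenyl gives a 4.7-fold higher number from compound 1 to compound 3 (0.67 log units; beyond the scatter), and isobutyl in place of 2,6-dichlorophenyl gives a 4.1-fold higher number from compound 2 to compound 3 (0.62 log units; beyond the scatter). Among these three compounds, then, the open chain goes with the highest number.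

Among the compounds with values here, the entering group also holds a ring, but a six-membered non-aromatic one with a hetero atom, and no measured compound carries such a ring on this carbonyl carbon. The evidence is therefore indirect. Going by a 4.1-fold higher number from compound 2 to compound 3 (0.62 log units; beyond the scatter), a modest move to a lower number is expected, though a smaller one than the measured steps. The expected change is a 2.4-fold lower number from compound 3 to compound 4 (0.37 log units; beyond the scatter). For compound 4 the estimate is 4000 nM, with a range of 1500 nM to 11000 nM.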

Compound 4, half-maximal inhibitory concentration: 4670 nM
For compound 4 the middle estimate is 1.2-fold (0.07 log units) below the measured one; the range from low to high includes it.
By their numbers in this assay, from the lowest: compounds 1 and 2 (each within the scatter of the next); then compounds 4 and 3 (each within the scatter of the next).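

In this assay 1-methylpiperidin-4-yl in place of isobutyl gives a 2.0-fold lower number from compound 3 to compound 4 (0.30 log units; within the scatter) and so, on this carbonyl carbon, the two groups cannot be told apart. Set against the two groups with an aromatic ring, the same entering group gives a 2.0-fold higher number from compound 2 to compound 4 (0.31 log units; beyond the scatter) and a 2.3-fold higher number from compound 1 to compound 4 (0.37 log units; beyond the scatter) as modest steps, which places compound 4 with compound 3 and apart from compound 1 and compound 2. Holding a ring is therefore not enough to reach the lower numbers here: among these four compounds, only the two with an aromatic ring on the carbonyl carbon, 4-methoxyphenyl and 2,6-dichlorophenyl, give them, and the six-membered non-aromatic ring does not. No measurement at hand explains why the groups fall into these two sets. The compounds shown leave open how a cyclohexyl ring, which has no nitrogen, would compare with compound 4, so the part played by the ring nitrogen stays unknown. They also leave open how an unsubstituted phenyl, or a longer chain ending in an amine, would read on this carbonyl carbon.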